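Amide Change at the Carbonyl: Methylamino to Morpholine

The source may report more compounds than this note shows. Statements on the series, on what has been measured and on what is new or still open speak of the compounds shown alone.

Measured compounds in a functional assay on HCT-116 cells (Homo sapiens) for inhibition, read by MTT assay, with a stated time of 72 h; a higher number here means a weaker inhibitor of growth, a lower number a stronger inhibitor of growth:
Compound 1 `CNC(=O)/C=C/c1ccncc1-c1ccc2ccccc2c1` gives 6550 nM
Compound 2 `CNC(=O)/C=C/c1ccncc1-c1ccc2cc[nH]c2c1` gives 10400 nM

Compound 1 carries the smaller of the two numbers, yet compound 2 sits within the usual scatter of it, so the two cannot be told apart as growth inhibitors. Compound 3 `O=C(/C=C/c1ccncc1-c1ccc2ccccc2c1)N1CCOCC1` is the next candidate; it differs from compound 1 by morpholin-4-yl in place of methylamino on a carbonyl carbon. Within the data shown here, no measured pair shows a change of this kind, so nothing here indicates its direction. The expectation is a step from compound 1 to compound 3 of about a 1.3-fold higher number from compound 1 to compound 3 (0.11 log units; within the scatter), within the scatter, perhaps leaning weaker. Compound 3 is therefore estimated at 8500 nM, with a range from 3000 nM to 25000 nM.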

Compound 3, concentration for 50% growth inhibition: 6040 nM
For compound 3 the middle estimate is 1.4-fold (0.15 log units) above the measured one, within the range that was stated.
By their numbers in this assay, from the lowest: compounds 3, 1 and 2 (each within the scatter of the next).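

In this assay the change to morpholin-4-yl in place of methylamino on a carbonyl carbon gives a 1.1-fold lower number from compound 1 to compound 3 (0.04 log units; within the scatter), so the two amides cannot be told apart. This position therefore takes a larger group with a ring, and loses the amide hydrogen, without any readable shift in growth inhibition. No measurement at hand offers an explanation for this result. On these data alone, whether a carboxylic acid or a longer chain on this carbonyl carbon would move the number beyond the scatter remains open. So does whether morpholin-4-yl behaves alike on the core of compound 2.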